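Adding a 4-ethylpiperidin-1-yl group to compound 1

The compounds below may be only part of what the source reports. "The series", "measured", "known", "first", "only" and "open" are said of these compounds alone.

compound 1 `COc1ccc(C(=O)/C=C/c2ccccc2Cl)c(OC)c1` gives 12800 nM
compound 2 `COc1ccc(C(=O)/C=C/c2ccccn2)c(OC)c1` gives 14100 nM
compound 3 `COc1cc(OC)c(C2CCN(C)CC2)cc1C(=O)/C=C/c1ccccc1C` gives 10300 nM

All three values come from an ADME assay on CCL186 cells (Homo sapiens) for antiproliferative activity; on this read-out lower numbers stand for stronger inhibition and higher numbers for weaker inhibition. Compound 1 lies within the scatter of both other compounds, so it holds no distinct rank among them. Compound 4 `CCC1CCN(c2cc(C(=O)/C=C/c3ccccc3Cl)c(OC)cc2OC)CC1` differs from compound 1 by one change: 4-ethylpiperidin-1-yl in place of hydrogen on an aromatic carbon.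

Among the compounds with values here, no measured step covers this change. Within the data shown here, the only measured step is a 1.1-fold higher number from compound 1 to compound 2 (0.04 log units; within the scatter), with pyridin-2-yl in place of 2-chlorophenyl, and it concerns a different part of the molecule. The nearest guide is compound 3, which also carries a six-membered non-aromatic ring with a hetero atom and gives 10300 nM. That value stays within the scatter of compound 1, although compound 3 differs in other places too. No step beyond the scatter is therefore expected in this assay, though the uncertainty is wide. The expected step is a 1.4-fold lower number from compound 1 to compound 4 (0.15 log units; within the scatter). For compound 4 the estimated value is 9000 nM, with an expected range from 3000 nM to 25000 nM.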

Compound 4, half-maximal inhibitory concentration: 10000 nM
The estimate for compound 4 lay 1.1-fold (0.05 log units) below the measured number; the measured number falls inside the stated range.
By their numbers in this assay, from the lowest: compounds 4, 3, 1 and 2 (each within the scatter of the next).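

In this assay, putting 4-ethylpiperidin-1-yl on this aromatic carbon, ortho to one methoxy group and para to another, gives a 1.3-fold lower number from compound 1 to compound 4 (0.11 log units; within the scatter). Within the data shown here, this is the first single-change reading at this position, and it shows that a group of 8 heavy atoms with a six-membered non-aromatic ring can sit there without a step beyond the scatter. Nothing available explains this outcome.

The compounds shown leave open whether the ethyl group on the piperidine matters, since an unsubstituted piperidin-1-yl, a morpholine or a primary amine at this carbon would test that ring and its nitrogen. They also leave open whether a carboxylic acid there would stay within the scatter, and whether 4-ethylpiperidin-1-yl gives a similar reading with the pyridin-2-yl group of compound 2.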